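Adding carboxymethyl to compound 3

The source may hold more compounds than are shown below. What is called first, only, known or untested is meant among the compounds shown, and "the series" means these compounds.

Values measured in an ADME assay on HepG2 2.2.15 cells (Homo sapiens) for cytotoxicity; a higher number here means that more compound is tolerated, a lower number that less compound is tolerated:

- compound 1 `Cn1c(=O)c(CCO)c(-c2ccccc2Cl)c2cc(Cl)ccc21`: 34000 nM
- compound 2 `C=CCn1c(=O)c(CCO)c(-c2ccccc2Cl)c2cc(Cl)ccc21`: 23000 nM
- compound 3 `CCC(=O)OCCc1c(-c2ccccc2Cl)c2cc(Cl)ccc2[nH]c1=O`: 95000 nM

Compound 3 has the highest number of the three, and its gap to each of the other two lies beyond the scatter. Compound 4 `O=C(O)CCCC(=O)OCCc1c(-c2ccccc2Cl)c2cc(Cl)ccc2[nH]c1=O` differs from compound 3 by carboxymethyl in place of hydrogen on a saturated chain carbon, two bonds along the chain from a carbonyl carbon. Among the measured compounds shown here, only one measured step exists, a 1.5-fold lower number from compound 1 to compound 2 (0.17 log units; within the scatter), and it lies within the scatter. That step was made at a different place, on a saturated chain carbon bound to an aromatic nitrogen, so it bears only weakly on this change. For the measured compounds named here, no measured step shows what this change does in this assay, so no shift beyond the scatter is expected. The expected result is a 1.1-fold lower number from compound 3 to compound 4 (0.02 log units; within the scatter). For compound 4 the estimate is 90000 nM, with an expected range of 40000 nM to 200000 nM.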

Compound 4, half-maximal cytotoxic concentration: 110000 nM
Estimate against measurement, compound 4: 1.2-fold (0.09 log units) below; the measured number falls inside the stated range.
By their numbers in this assay, from the lowest: compounds 2 and 1 (each within the scatter of the next); then compounds 3 and 4 (each within the scatter of the next).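

In this assay, carboxymethyl in place of hydrogen on a saturated chain carbon, two bonds along the chain from a carbonyl carbon, gives a step within the scatter (a 1.2-fold higher number from compound 3 to compound 4 (0.06 log units; within the scatter)). Among the compounds shown here, this is the first measured step at this position, and it shows that the added group leaves the tolerated concentration essentially unmoved. Nothing measured here accounts for this result. On these data alone, whether an amine or a longer chain at this position would also stay within the scatter remains open.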